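A few compounds are considered here, and "the series" means these few. Any claim that something is new, unique, unknown or untested is made for them only; others in the source may bear on it.

Measured compounds and their numbers:

Compound 1, `O=C(NCCC1CC1)c1ccc(N2CCC(Oc3ccccc3C(F)(F)F)CC2)nn1`, gives 14 nM in an assay on microsomes from liver for inhibition of acyl-CoA desaturase 1 (Rattus norvegicus); on this read-out higher numbers stand for weaker inhibition and lower numbers for stronger inhibition.
Compound 2, `Cc1ccccc1OC1CCN(c2ccc(-n3ccnc3)nn2)CC1`, gives 39 nM in this assay.
Compound 3, `Brc1cccc(OC2CCN(c3ccc(-n4ccnc4)nn3)CC2)c1`, gives 23 nM in this assay.

Of these three, compound 2 gives the largest number, which on this read-out means the weakest inhibition. Only compound 1 lies beyond the scatter from it, with the lower number; compound 3 sits within the scatter of compound 2, so the two cannot be told apart.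

The new compound is compound 4, `CCc1cccc(OC2CCN(c3ccc(-n4ccnc4)nn3)CC2)c1`. Compared with compound 2 the change is 3-ethylphenyl in place of 2-methylphenyl on an oxygen on a saturated carbon. For the measured compounds named here, the one measured step that bears on this is the move from compound 2 to compound 3, where a 3-bromophenyl took the place of the 2-methylphenyl at the same oxygen and gave a 1.7-fold lower number from compound 2 to compound 3 (0.23 log units; within the scatter). That step did not rise above the scatter. Compound 4 makes a change of the same kind at the same place, with a 3-ethylphenyl entering instead, and with a single comparison to go on, no step beyond the scatter is expected in this assay.

The step expected is a 1.3-fold lower number from compound 2 to compound 4 (0.11 log units; within the scatter), within the scatter. Compound 4 is therefore estimated at 30 nM, with a range from 12 nM to 75 nM.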

Compound 4, half-maximal inhibitory concentration: 38 nM
The estimate for compound 4 lay 1.3-fold (0.10 log units) below the measured number; low and high end bracket the measured number.
By their numbers in this assay, from the lowest: compounds 1, 3, 4 and 2 (each within the scatter of the next, the first and the last beyond it).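

In this assay the 3-ethylphenyl group on this oxygen gives a 1.0-fold lower number from compound 2 to compound 4 (0.01 log units; within the scatter) and so joins 3-bromophenyl as a second replacement for 2-methylphenyl that cannot be told apart from it. The direct comparison of the two replacements, with ethyl in place of bromo on an aromatic carbon, gives a 1.7-fold higher number from compound 3 to compound 4 (0.22 log units; within the scatter) and shows that these two groups cannot be separated either, so compounds 2, 3 and 4 form a set with no measurable difference among them, even though 3-ethylphenyl has 8 heavy atoms and 2-methylphenyl has 7. Nothing available here offers an explanation for why these three groups read alike in this assay.

As far as these compounds go, these three compounds cover only small carbon or halogen groups on the phenyl ring, so it remains open whether a longer chain such as butyl, an amine or a carboxylic acid on that ring would produce a step beyond the scatter. From the compounds shown here alone, it also remains open whether any group at this place can move the number by more than the scatter while the rest of the molecule stays the same.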